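The source may report more compounds than this note shows. Statements on the series, on what has been measured and on what is new or still open speak of the compounds shown alone.

Within the data shown here, in an ADME assay on the whole organism (Rattus norvegicus, strain Sprague-Dawley) for metabolic stability (on this read-out lower numbers stand for a shorter-lived compound and higher numbers for a longer-lived compound), compound 1 (`NC(=O)c1cc(-c2ccccc2)cc2c(C3CCN(S(=O)(=O)CCCN4CCCC4)CC3)c[nH]c12`) gives 4.6 h and holds the higher of the two numbers so far, a gap beyond the scatter from compound 2 (`NC(=O)c1cc(-c2ccccc2)cc2c(C3CCS(=O)(=O)CC3)c[nH]c12`), which gives 1.58 h on the same scale. Compound 3 (`CCS(=O)(=O)N1CCC(c2c[nH]c3c(C(N)=O)cc(-c4ccccc4)cc23)CC1`) differs from compound 1 by hydrogen in place of (pyrrolidin-1-yl)methyl on a saturated chain carbon, two bonds along the chain from a sulfonyl sulfur in one place, turning (3-(pyrrolidin-1-yl)propyl)sulfonyl into ethylsulfonyl. Among the measured compounds shown here, no measured pair shows this change alone, so the size of the step in this assay is a judgement: a moderate fall is expected, and compound 2 at 1.58 h is the only other guide. The estimated change is a step of a 2.3-fold lower number from compound 1 to compound 3 (0.36 log units; beyond the scatter) overall. Compound 3 is expected at 2 h (range 1 h to 4 h).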

Compound 3, half-life: 1.15 h
The estimate for compound 3 lay 1.7-fold (0.24 log units) above the measured number; low and high end bracket the measured number.
By their numbers in this assay, from the lowest: compounds 3 and 2 (each within the scatter of the next); then compound 1.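

In this assay, trimming (3-(pyrrolidin-1-yl)propyl)sulfonyl to ethylsulfonyl gives a 4.0-fold lower number from compound 1 to compound 3 (0.60 log units; beyond the scatter), so the group at this sulfonyl does bear on how long the compound lasts in the rat. Nothing available explains this step. Still open, from the compounds shown here alone, is whether the pyrrolidine ring or the length of the chain carries the difference. A plain propyl chain, or a propyl chain ending in a dimethylamine or a carboxylic acid, would help to tell these apart.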